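Swapping a Fluorophenyl for a tert-Butyl on Two Cores

This account rests on a few compounds, and the source may have more. Where it says the series, first, only, none or still open, it means among the compounds named here.

Of the compounds shown here, three have so far been tested in an ADME assay on Vero cells (Chlorocebus sabaeus) for cytotoxicity, read by MTT assay, with a stated time of 72 h; on this read-out higher numbers stand for weaker inhibition and lower numbers for stronger inhibition. Compound 1 `O=C(O)c1cn(-c2ccc(F)cc2)c2nc(N3CCC(n4c(=O)[nH]c5cc(Cl)ccc54)CC3)c([N+](=O)[O-])cc2c1=O` gives 53900 nM in this assay. Compound 3 `CC(C)(C)n1cc(C(=O)O)c(=O)c2cc([N+](=O)[O-])c(N3CCC(n4c(=O)[nH]c5cc(Cl)ccc54)CC3)nc21` gives 57700 nM in this assay. These two differ in one place, (tert-butyl in place of 4-fluorophenyl on an aromatic nitrogen), and the step was a 1.1-fold higher number from compound 1 to compound 3 (0.03 log units; within the scatter). Compound 2 `O=C(O)c1cn2c(n1)CN(c1nc3c(cc1[N+](=O)[O-])c(=O)c(C(=O)O)cn3-c1ccc(F)cc1)CC2` is built on a different core, and how its core differs from that of compound 1 is not broken down here. In this assay compound 2 reaches only a limit of > 126000 nM, which is not a number but the edge of what the assay reports. That limit is the limit of > 126000 nM in this assay, at which 1 of the 3 values shown sits. Compound 4 `CC(C)(C)n1cc(C(=O)O)c(=O)c2cc([N+](=O)[O-])c(N3CCn4cc(C(=O)O)nc4C3)nc21` has not yet been measured; it differs from compound 2 by the same change, (tert-butyl in place of 4-fluorophenyl on an aromatic nitrogen), made at the same place. Because the same change gave a 1.1-fold higher number from compound 1 to compound 3 (0.03 log units; within the scatter), the step from compound 2 to compound 4 is expected to be about a step that the limit leaves unreadable from compound 2 to compound 4. Compound 4 is therefore estimated at 150000 nM, between 60000 nM and 350000 nM, with a good chance that this assay again reports only a limit.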

Compound 4, half-maximal inhibitory concentration: > 136000 nM
Compound 4: a limit, no number; the forecaster's own chance of this, stated with the estimate: 75%; the middle value lies beyond the limit too.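

In this assay compound 2 gives only a limit, > 126000 nM. Compound 4 likewise gives only a limit, > 136000 nM. Among these compounds, no step from compound 2 to compound 4 can be read from these two limits. The compounds shown leave open whether tert-butyl in place of 4-fluorophenyl changes anything on the core of compound 2.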